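The source may report more compounds than this note shows. Statements on the series, on what has been measured and on what is new or still open speak of the compounds shown alone.

In a toxicity assay on L02 cells (Homo sapiens) for cytotoxicity, read by MTT assay, with a stated time of 72 h (a lower number here means a stronger inhibitor, a higher number a weaker inhibitor), compound 2 `O=C1c2c[n+]([O-])c3ccccc3c2C(=O)c2c1c1ccccc1n2Cc1cn(C[C@H](O)CO)nn1` gives 1130 nM, the highest number among the three measured compounds; compound 1 `CN(C)CCCCCn1c2c(c3ccccc31)C(=O)c1c[n+]([O-])c3ccccc3c1C2=O` gives 240 nM and compound 3 `CN(C)CCCCn1c2c(c3ccccc31)C(=O)c1c[n+]([O-])c3ccccc3c1C2=O` gives 300 nM. Compound 4 `O=C1c2c[n+]([O-])c3ccccc3c2C(=O)c2c1c1ccccc1n2CCCN1CCC(O)CC1` differs from compound 2 in one place: 2-(4-hydroxypiperidin-1-yl)ethyl in place of 1-(2,3-dihydroxypropyl)-1H-1,2,3-triazol-4-yl on a saturated chain carbon bound to an aromatic nitrogen. For the measured compounds named here, two measured steps bear on this change. The step of a 4.7-fold higher number from compound 1 to compound 2 (0.67 log units; beyond the scatter) and the step of a 3.8-fold lower number from compound 2 to compound 3 (0.58 log units; beyond the scatter) both show the chain carrying the 1-(2,3-dihydroxypropyl)-1H-1,2,3-triazol-4-yl group giving a higher number than a chain ending in a dimethylamino group, while a 1.3-fold higher number from compound 1 to compound 3 (0.10 log units; within the scatter) shows that chain length alone changes little. Compound 4 again ends its chain in a nitrogen-bearing group, the 2-(4-hydroxypiperidin-1-yl)ethyl, so a drop of similar size is expected, a 3.2-fold lower number from compound 2 to compound 4 (0.51 log units; beyond the scatter). Compound 4 is therefore estimated at 350 nM, between 150 nM and 900 nM.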

Compound 4, half-maximal inhibitory concentration: 120 nM
For compound 4 the middle estimate is 2.9-fold (0.46 log units) above the measured one; the measured number lies below the stated range.
By their numbers in this assay, from the lowest: compounds 4, 1 and 3 (each within the scatter of the next, the first and the last beyond it); then compound 2.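

In this assay, the 3-(4-hydroxypiperidin-1-yl)propyl chain gives a 9.4-fold lower number from compound 2 to compound 4 (0.97 log units; beyond the scatter), so a hydroxyl-bearing six-membered ring at the chain end fits this position at least as well as a dimethylamino end. Against the dimethylamino compounds the result is mixed: a 2.5-fold lower number from compound 3 to compound 4 (0.40 log units; beyond the scatter) lies beyond the scatter, while a 2.0-fold lower number from compound 1 to compound 4 (0.30 log units; within the scatter) lies within it. The data therefore give no clear gain over both dimethylamino chains.

Nothing available explains these differences. A plain piperidin-1-yl or morpholin-4-yl group on the same propyl chain would show whether the hydroxyl matters.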